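Aromatase series: fluorophenyl to methoxyphenyl on compound 3

The compounds below may be only part of what the source reports. "The series", "measured", "known", "first", "only" and "open" are said of these compounds alone.

Measured so far in an assay on isolated protein for inhibition of Aromatase (Homo sapiens), read by ELISA, using NADPH, with a stated time of 24 h; a higher number here means a weaker inhibitor, a lower number a stronger inhibitor:
compound 1 `COc1ccc(-c2[nH]c3cc(Cl)ccc3c2Cn2ccnc2)cc1`: 277 nM
compound 2 `Fc1ccc(-c2[nH]c3cc(F)ccc3c2Cn2cncn2)cc1`: 54.4 nM
compound 3 `Fc1ccc(-c2[nH]c3cc(Cl)ccc3c2Cn2cncn2)cc1`: 96.9 nM

Compound 3 holds the second highest of the three numbers; its nearest neighbour is compound 2, and the step of a 1.8-fold higher number from compound 2 to compound 3 (0.25 log units; within the scatter) lies within the scatter, while compound 1 stands a larger gap above it. The next compound, compound 4 `COc1ccc(-c2[nH]c3cc(Cl)ccc3c2Cn2cncn2)cc1`, differs from compound 3 by methoxy in place of fluoro on an aromatic carbon. Within the data shown here, no measured pair isolates this change: compound 1 and compound 3 differ here and in a second place as well, so their two values show only that compound 1 sits higher. Among the measured compounds shown here, the single measured step concerns another position and was within the scatter. For compound 4 a modest rise in this assay is therefore expected, a 1.5-fold higher number from compound 3 to compound 4 (0.19 log units; within the scatter), with wide uncertainty. The estimate for compound 4 is 150 nM, range 60 nM to 400 nM.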

Compound 4, half-maximal inhibitory concentration: 197 nM
Beside the measured number, compound 4's estimate is 1.3-fold (0.12 log units) below it; measured number inside the range.
By their numbers in this assay, from the lowest: compounds 2 and 3 (each within the scatter of the next); then compounds 4 and 1 (each within the scatter of the next).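

With chloro held on the shared core, 4-fluorophenyl to 4-methoxyphenyl can now be read on its own in this assay (a 2.0-fold higher number from compound 3 to compound 4 (0.31 log units; beyond the scatter)), a modest step. Among these compounds, the 1H-1,2,4-triazol-1-yl for 1H-imidazol-1-yl change can also be read alone for the first time (a 1.4-fold lower number from compound 1 to compound 4 (0.15 log units; within the scatter)), and with 4-methoxyphenyl in place it stays within the scatter. Nothing at hand bears on the cause of either step.

Open, going by these compounds, is how an amine or a longer alkoxy chain in place of methoxy would read. Also open, on these data alone, is whether the methoxy step holds with fluoro in place of chloro on the core.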